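The source may report more compounds than this note shows. Statements on the series, on what has been measured and on what is new or still open speak of the compounds shown alone.

Measured compounds:
- compound 1, `Nc1ccccc1NC(=O)c1ccc(Cn2cnc3c(NCc4ccccc4)nc(Cl)nc32)cc1`: 62.8%
- compound 2, `CCCCn1cnc2c(Nc3ccccc3)nc(NCOCc3ccc(/C=C/C(=O)Nc4ccccc4N)cc3)nc21`: 59.3%

In a functional assay on HepG2 cells (Homo sapiens) for antiproliferative activity, read by CCK-8 assay, with a stated time of 72 h, tested at 8 uM (on this read-out lower numbers stand for a weaker effect and higher numbers for a stronger effect at the one concentration tested), compound 1 gives 62.8%. In this assay compound 2 gives 59.3%. Going by the values given here, compound 1 has the higher of the two numbers, but its only neighbour, compound 2, sits within the scatter of it, so the two read-outs show no difference that can be relied on. Both values sit in the same middle region of the scale.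

Compound 3, `Nc1ccccc1NC(=O)c1ccc(Cn2cnc3c(Nc4cccc(Cl)c4)nc(Cl)nc32)cc1`, has not yet been tested in this assay. It differs from compound 1 in one place: 3-chlorophenyl in place of benzyl on a nitrogen on an aromatic ring. Among the compounds with values here, no pair of measured compounds shows this change, so there is no measured step to lean on; the only guidance is the value of compound 1, 62.8%, and the fact that compound 2 lands close to it. The account therefore expects no step beyond the scatter, in either direction, with a number 2.8 percentage points lower from compound 1 to compound 3 (within the scatter) as the expected step. For compound 3 the estimated value in this assay is 60%, within a range from 45% to 75%.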

Compound 3, a percentage reported as inhibition, at one concentration (the size of the read-out at that concentration, not a potency): 66.7%
The estimate for compound 3 lay 6.7 percentage points below the measured number, within the range that was stated.
By their numbers in this assay, from the lowest: compounds 2, 1 and 3 (each within the scatter of the next).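

In this assay, going by these compounds alone, 3-chlorophenyl in place of benzyl on a nitrogen on an aromatic ring gives a number 3.9 percentage points higher from compound 1 to compound 3 (within the scatter), the first measured step at this position. The change therefore moves the read-out by no amount that can be relied on, and the benzylamino and (3-chlorophenyl)amino forms of the shared core cannot be told apart here. No accompanying measurement bears on why the two groups read alike.

A single change at this place cannot show whether a cyclohexyl group or a longer chain such as phenethyl on this nitrogen would move the number beyond the scatter. Whether an amine or a methoxy group in place of the chlorine on the shared core would shift the read-out also stays open, and a reading at one concentration leaves the potency of these compounds undecided.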